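The source may hold more compounds than are shown below. What is called first, only, known or untested is meant among the compounds shown, and "the series" means these compounds.

Working notes on the series. Compound 1 `COc1cc(-c2cc(/C=C/C(=O)c3ccc(N)cc3)[nH]n2)cc(OC)c1OC` is the reference; in a functional assay on NCI-H226 cells (Homo sapiens) for cytotoxicity, read by sulforhodamine B assay, with a stated time of 48 h, tested at 0.01 uM (a higher number here means a weaker effect of the compound at the concentration tested, a lower number a stronger effect), compound 1 gives 92%. Compound 2 `COc1ccc(C(=O)/C=C/c2cc(-c3cc(OC)c(OC)c(OC)c3)n[nH]2)cc1OC` carries a different aryl group on the carbonyl, and in this assay compound 2 gives 98%. Compound 3 `COc1ccc(C(=O)/C=C/c2cc(-c3cc(OC)c(OC)c(OC)c3)n[nH]2)cc1` in this assay gives 99%. The steps of a number 6 percentage points higher from compound 1 to compound 2 (within the scatter) and a number 7 percentage points higher from compound 1 to compound 3 (within the scatter) both sit within the scatter.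

The cores of compound 1 and compound 2 differ as follows: 4-aminophenyl in place of 3,4-dimethoxyphenyl on a carbonyl carbon.

Compound 4 `COc1ccc(-c2cc(/C=C/C(=O)c3ccc(N)cc3)[nH]n2)cc1OC` is not yet measured. It is derived from compound 1 by hydrogen in place of methoxy on an aromatic carbon. The same kind of change is already seen between measured compounds: hydrogen in place of methoxy on an aromatic carbon, which gave a number 1 percentage points higher from compound 2 to compound 3 (within the scatter). The two places are not the same word for word: in compound 1 the carbon is also meta to a methoxy group (2 heavy atoms), whereas in compound 2 it is not.

Because a number 1 percentage points higher from compound 2 to compound 3 (within the scatter) lies within the scatter, the step from compound 1 to compound 4 is expected to be about as small, estimated as a number 1 percentage points higher from compound 1 to compound 4 (within the scatter). For compound 4 the expected value in this assay is 93%, estimated between 82% and 100%.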

Compound 4, a percentage reported as activity, at one concentration (the size of the read-out at that concentration, not a potency): 93%
Compound 4: the middle estimate sits on the measured number at the digits printed; the range from low to high includes it.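

In this assay, hydrogen in place of methoxy on an aromatic carbon gives a number 1 percentage points higher from compound 1 to compound 4 (within the scatter), and the same change on the other core reads alike: the same change on two cores in this assay, a number 1 percentage points higher (within the scatter) from compound 2 to compound 3 and a number 1 percentage points higher (within the scatter) from compound 1 to compound 4, 0 percentage points apart, within the scatter of two such steps. On these two cores the change therefore carries over with a step inside the scatter each time, even though the carbon it sits on has different surroundings in the two cores. This does not show that the change is without effect in general: it rests on two pairs read at one low concentration, and two small steps that agree say little about how the change would behave at a concentration where the compounds act more strongly.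

The compounds shown leave open whether a hydroxyl or an ethoxy group on that same aromatic carbon would read alike. They also leave open whether the agreement would hold on a core carrying a carboxylic acid in place of the amino group.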